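The source may hold more compounds than are shown below. What is called first, only, known or untested is meant among the compounds shown, and "the series" means these compounds.

Measured compounds:

Compound 1 `CCC(=O)c1ccc2c(c1O)[C@@H]1c3c(ccc4c(=O)c(C)c(C)oc34)OC[C@@H]1C(C)(C)O2`: in a functional assay on MCF7 cells (Homo sapiens) for cytotoxicity, read by MTT assay (on this read-out lower numbers stand for stronger inhibition and higher numbers for weaker inhibition), compound 1 gives > 100000 nM, which is a limit of the assay and not a number.
Compound 2 `CC(=O)c1ccc2c(c1O)[C@@H]1c3c(ccc4c(=O)c(C)c(C)oc34)OC[C@@H]1C(C)(C)O2`: in this assay compound 2 gives > 100000 nM, again a limit.
Compound 3 `CCC(=O)c1ccc2c(c1O)[C@H]1c3c(ccc4c(=O)c(C)coc34)OC[C@H]1C(C)(C)O2`: in this assay compound 3 gives > 100000 nM, also a limit.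

Compound 3 therefore stands only at a limit, as do the other two values, all sitting at the limit of > 100000 nM in this assay, at which 3 of the 3 values shown sit. The unmeasured compound 4 `CC(=O)c1ccc2c(c1O)[C@H]1c3c(ccc4c(=O)c(C)coc34)OC[C@H]1C(C)(C)O2` differs from compound 3 by hydrogen in place of methyl on a saturated chain carbon bound to a carbonyl carbon. The same change is measured once, as a step that the two limits leave unreadable from compound 1 to compound 2, but the two limits leave its size unreadable. For the measured compounds named here, no measured step shows any movement; the expected step of a number no higher from compound 3 to compound 4 (the limit leaves the size open) is none beyond the scatter. Compound 4 is accordingly expected at 100000 nM, between 40000 nM and 300000 nM, most likely again reported only as a limit.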

Compound 4, half-maximal inhibitory concentration: > 100000 nM
Compound 4 ended at the assay's limit; the forecaster's own chance of this, stated with the estimate: 90%; the middle value lies on the limit itself.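

No step can be read between compound 3 and compound 4 in this assay, as both values are limits of the assay and not numbers: the limit of > 100000 nM in this assay, at which 4 of the 4 values shown sit.

The compounds shown leave open whether propanoyl or acetyl makes any difference to cytotoxicity.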